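Lengthening the hydroxycarbamoyl chain of compound 1

This account rests on a few compounds, and the source may have more. Where it says the series, first, only, none or still open, it means among the compounds named here.

Of the compounds shown here, two have numbers so far. In a functional assay on A549 cells (Homo sapiens) for inhibition (a higher number here means a weaker inhibitor, a lower number a stronger inhibitor), compound 1 `CC(C)c1cc(-c2n[nH]c(=O)n2-c2cccc(NC(=O)CCCCCC(=O)NO)c2)c(O)cc1O` gives 1600 nM, and compound 2 `CC(C)c1cc(-c2n[nH]c(=O)n2-c2ccc(C(=O)NCCCCCCC(=O)NO)cc2)c(O)cc1O` gives 4600 nM. Compound 1 therefore holds the lower of the two numbers, and the gap lies beyond the scatter.

Compound 3 `CC(C)c1cc(-c2n[nH]c(=O)n2-c2cccc(NC(=O)CCCCCCC(=O)NO)c2)c(O)cc1O` keeps the core of compound 1 and differs only in the chain: (hydroxycarbamoyl)methyl in place of hydroxycarbamoyl on a saturated chain carbon, five bonds along the chain from a carbonyl carbon. This places (hydroxycarbamoyl)methyl in place of hydroxycarbamoyl on a saturated chain carbon, five bonds along the chain from a carbonyl carbon. For the measured compounds named here, no measured pair isolates a change of this kind, so the data offer no direct guide to its size. In this assay only a small shift toward a lower number is expected, one that stays within the scatter: the estimated change is a 1.3-fold lower number from compound 1 to compound 3 (0.12 log units; within the scatter). Compound 3 is estimated at 1200 nM, with an expected range of 400 nM to 3600 nM.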

Compound 3, half-maximal inhibitory concentration: 1600 nM
Compound 3: middle estimate off by 1.3-fold (0.12 log units), on the low side, within the range that was stated.
By their numbers in this assay, from the lowest: compounds 1 and 3 (each within the scatter of the next); then compound 2.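

In this assay, (hydroxycarbamoyl)methyl in place of hydroxycarbamoyl on a saturated chain carbon, five bonds along the chain from a carbonyl carbon, gives no change at the digits printed from compound 1 to compound 3 (within the scatter). For the compounds shown here, this is the first pair that isolates a single change, and it shows that the chain of compound 1 can take this change at this place without a shift beyond the scatter. Nothing measured here bears on why the number holds.

Still open, on these data alone, is whether the number also holds for a longer chain, such as 2-(hydroxycarbamoyl)ethyl or 3-(hydroxycarbamoyl)propyl at the same place. Also open, as far as these compounds go, is how the number responds when the hydroxycarbamoyl end itself gives way to a carboxylic acid or an amine.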